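Cytotoxicity in Dog Kidney Cells: Methyl to Difluorobenzyl

A few compounds are considered here, and "the series" means these few. Any claim that something is new, unique, unknown or untested is made for them only; others in the source may bear on it.

Measured compounds:
Compound 1 `COC(=O)C[C@H](NC(=O)OC(C)(C)C)C(=O)N(Cc1ccc(F)cc1)C1(C(=O)NCS(=O)(=O)c2ccc(C)cc2)CCN(Cc2ccccc2)CC1` gives 4000 nM in an ADME assay on MDCK cells (Canis lupus familiaris) for cytotoxicity, read by microscopy, with a stated time of 72 h; on this read-out higher numbers stand for lower toxicity in this test and lower numbers for higher toxicity in this test.
Compound 2 `COC(=O)C[C@H](NC(=O)OC(C)(C)C)C(=O)N(C)C1(C(=O)NCc2ccccc2)CCN(Cc2ccccc2)CC1` gives 20000 nM in this assay.

Of the two measured compounds, compound 2 stands at the higher number, meaning the lower toxicity in this test, and the gap to compound 1 lies beyond the scatter of repeated measurements. Compound 1, however, differs from compound 2 in more than one place, so the two values show only where each stands, not what any single change does.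

Compound 3 `COC(=O)C[C@H](NC(=O)OC(C)(C)C)C(=O)N(Cc1ccc(F)c(F)c1)C1(C(=O)NCc2ccccc2)CCN(Cc2ccccc2)CC1` is the compound to be measured. It keeps the core of compound 2 and differs from it in one place: 3,4-difluorophenyl in place of hydrogen on a saturated chain carbon bound to an amide-type nitrogen. Among the measured compounds shown here, no measured pair isolates this change, so its effect can only be expected, not read off. For the measured compounds named here, since compound 1, the only other measured compound, carries a related aromatic group on the same nitrogen and gives 4000 nM, a move toward lower numbers in this assay seems more likely than a move upward, of a size beyond the scatter but smaller than the gap between the two measured compounds. The expected step is a 2.5-fold lower number from compound 2 to compound 3 (0.40 log units; beyond the scatter). For compound 3 the estimate in this assay is 8000 nM, with a range from 3000 nM to 20000 nM.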

Compound 3, minimum cytotoxic concentration: 20000 nM
Estimate against measurement, compound 3: 2.5-fold (0.40 log units) below, and the stated range covers the measured number.
By their numbers in this assay, from the lowest: compound 1; then compounds 2 and 3 (each within the scatter of the next).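

Putting 3,4-difluorophenyl in place of hydrogen on a saturated chain carbon bound to an amide-type nitrogen, which turns a methyl into a 3,4-difluorobenzyl, gives no change at the digits printed from compound 2 to compound 3 (within the scatter) in this assay. Among the compounds shown here, this is the first single change that can be read at this position, and it shows that the nitrogen of the core of compound 2 can carry this much larger aromatic group with no detectable shift toward higher toxicity in this test. Nothing measured here offers a reason for this result.

The lower number of compound 1, at 4000 nM, still cannot be traced to any single change, as that compound differs from compound 2 in more than one place. Also open, from the compounds shown here alone, is whether the same flat result would hold on this nitrogen for a different kind of group, such as a chain ending in an amine or a carboxylic acid, or a longer chain between the nitrogen and the 3,4-difluorophenyl ring.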